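The compounds below may be only part of what the source reports. "The series", "measured", "known", "first", "only" and "open" are said of these compounds alone.

Of the compounds shown here, three sharing one core have been measured in an assay on isolated protein for inhibition of Tryptophan 2,3-dioxygenase (Homo sapiens), read by spectrophotometry, with a stated time of 1 h; on this read-out higher numbers stand for weaker inhibition and lower numbers for stronger inhibition. Compound 1 `O=[N+]([O-])c1ccc(N/C(=N\O)c2ccccc2Br)c2nonc12` gives 25000 nM. Compound 2 `O=[N+]([O-])c1ccc(N/C(=N\O)c2cccc(F)c2)c2nonc12` gives 45000 nM. Compound 3 `O=[N+]([O-])c1ccc(N/C(=N\O)c2ccc(Cl)cc2)c2nonc12` gives 40000 nM, and its steps to the other two, a 1.6-fold higher number from compound 1 to compound 3 (0.20 log units; within the scatter) and a 1.1-fold lower number from compound 2 to compound 3 (0.05 log units; within the scatter), both stay within the scatter, so compound 3 cannot be set apart from either of them. Compound 4 `O=[N+]([O-])c1ccc(N/C(=N\O)c2ccc(F)c(Br)c2)c2nonc12` carries 3-bromo-4-fluorophenyl in place of 4-chlorophenyl on a carbon with a double bond to nitrogen. The two measured steps that also swap one halogenated phenyl for another, a 1.6-fold higher number from compound 1 to compound 3 (0.20 log units; within the scatter) and a 1.1-fold lower number from compound 2 to compound 3 (0.05 log units; within the scatter), were both within the scatter, so no step beyond the scatter is expected in this assay for compound 4, and the step expected from compound 3 to compound 4 is a 1.1-fold lower number from compound 3 to compound 4 (0.06 log units; within the scatter). Compound 4 is therefore estimated at 35000 nM, with a range from 15000 nM to 80000 nM.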

Compound 4, half-maximal inhibitory concentration: 47000 nM
Compound 4: middle estimate off by 1.3-fold (0.13 log units), on the low side; measured number inside the range.
By their numbers in this assay, from the lowest: compounds 1, 3, 2 and 4 (each within the scatter of the next).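

In this assay, the 3-bromo-4-fluorophenyl group, with two halogens on the ring, gives no step beyond the scatter from any single-halogen phenyl group: a 1.2-fold higher number from compound 3 to compound 4 (0.07 log units; within the scatter), a 1.0-fold higher number from compound 2 to compound 4 (0.02 log units; within the scatter) and a 1.9-fold higher number from compound 1 to compound 4 (0.27 log units; within the scatter). All four halogenated phenyl groups at this position therefore remain indistinguishable in this read-out. Nothing available here accounts for this flat result.

Still open, from the compounds shown here alone, is whether a phenyl ring carrying an amine or a carboxylic acid, or a longer chain in place of the phenyl, would move the number beyond the scatter.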